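Lengthening a Chain in a Cytotoxicity Screen

The compounds below may be only part of what the source reports. "The series", "measured", "known", "first", "only" and "open" are said of these compounds alone.

Compound 1 `O=C1N(CCCCCCCOc2ccc(Br)cc2)CCN1c1ccncc1` and compound 2 `O=C1N(CCCCCCOc2ccc(Br)cc2)CCN1c1ccncn1` share a core and differ in the length of the chain carrying the 4-bromophenoxy group. In a functional assay on cells (Homo sapiens) for cytotoxicity (a higher number here means that more compound is tolerated, a lower number that less compound is tolerated), compound 1 reaches only the assay limit of > 25000 nM. In this assay compound 2 likewise reaches only the limit of > 25000 nM. Compound 2 thus stands where every value shown stands, since (the limit of > 25000 nM in this assay, at which 2 of the 2 values shown sit). Compound 3 `O=C1N(CCCCCCCOc2ccc(Br)cc2)CCN1c1ccncn1` arises from compound 2 by (4-bromophenoxy)methyl in place of 4-bromophenoxy on a saturated chain carbon, six bonds along the chain from an amide-type nitrogen in a ring. Going by the values given here, no measured step exists here, so no change beyond the scatter is expected. Compound 3 is estimated at 40000 nM, within 25000 nM to 100000 nM. The expected step is a step that the limit leaves unreadable from compound 2 to compound 3.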

Compound 3, half-maximal cytotoxic concentration: > 25000 nM
Compound 3 gave a limit, no number; the forecaster's own chance of this, stated with the estimate: 85%; the middle value lies beyond the limit too.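

Going by these compounds alone, compound 1, compound 2 and compound 3 each give only a limit in this assay, so no step between them can be read: the limit of > 25000 nM in this assay, at which 3 of the 3 values shown sit. As far as these compounds go, whether lengthening the chain or replacing pyridin-4-yl with pyrimidin-4-yl changes the tolerated concentration remains open.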